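The source may report more compounds than this note shows. Statements on the series, on what has been measured and on what is new or still open speak of the compounds shown alone.

A small set of compounds has been tested in an ADME assay on L6 cells (Rattus norvegicus) for cytotoxicity, read by resazurin assay, with a stated time of 72 h; on this read-out lower numbers stand for stronger inhibition and higher numbers for weaker inhibition. Compound 1 `O=[N+]([O-])c1nccn1CCCNS(=O)(=O)c1cc(Cl)c(Cl)s1` gives 75000 nM there, and compound 2 `Cc1csc(C(=O)NCCCn2cnc([N+](=O)[O-])n2)c1` gives 173000 nM. For compound 3 `O=C(NCCCCn1ccnc1[N+](=O)[O-])c1ccsc1` the entry reads "not determined" (no result reported), so it offers no comparison. Compound 2 therefore has the higher of the two available numbers, and its gap to compound 1 lies beyond the usual scatter of repeated measurements.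

Compound 4 `Cc1cc(C(=O)NCCCn2cnc([N+](=O)[O-])n2)c(C)o1` has not been measured yet. It keeps the rest of compound 2 and alters only the group on the amide carbonyl: 2,5-dimethylfuran-3-yl in place of 4-methylthiophen-2-yl on a carbonyl carbon. In words, 2,5-dimethylfuran-3-yl stands in place of 4-methylthiophen-2-yl on a carbonyl carbon. For the measured compounds named here, both groups contain one five-membered aromatic ring with 1 hetero atom, but no measured pair here shows what such an exchange does. The expectation therefore rests on compound 2 at 173000 nM, and no change beyond the scatter is expected in this assay. The expected size of the change is a 1.2-fold lower number from compound 2 to compound 4 (0.06 log units; within the scatter). For compound 4 the estimated value is 150000 nM, with an expected range from 70000 nM to 300000 nM.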

Compound 4, half-maximal inhibitory concentration: > 341000 nM
Compound 4 gave a limit, no number (the forecaster's own chance of this, stated with the estimate: 15%); middle value at least 2.2-fold (0.35 log units) away from the limit.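

The result for compound 4 in this assay is a limit of the assay and not a number: the limit of > 341000 nM in this assay, at which 1 of the 4 values shown sits. For the compounds shown here, the exchange of 4-methylthiophen-2-yl for 2,5-dimethylfuran-3-yl on a carbonyl carbon provides the first measured pair that differs in one place, and it amounts to an at least 1.9-fold higher number from compound 2 to compound 4 (0.29 log units; that floor lies within the scatter). Going by these compounds, this pair gives no sign of stronger inhibition of the cells when one five-membered aromatic ring with 1 hetero atom replaces the other at this position, but the floor does not establish a real rise, and the true size of the step remains unknown.

The compounds shown leave open what a phenyl or pyridine ring would do on this carbonyl carbon, and what an aminomethyl group or a carboxylic acid would do on the five-membered ring. They also leave open whether the same exchange would have a similar effect with a longer chain on the amide nitrogen, since this single pair shares one chain length and cannot speak for others.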